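The source may hold more compounds than are shown below. What is called first, only, known or untested is meant among the compounds shown, and "the series" means these compounds.

Compound 1 `COc1cc(-c2cc(/C=C/C(=O)c3ccc(N)cc3)[nH]n2)cc(OC)c1OC` gives 82%; compound 2 `COc1ccc(-c2cc(/C=C/C(=O)c3cc(OC)c(OC)c(OC)c3)[nH]n2)cc1OC` gives 68%; compound 3 `COc1ccc(C(=O)/C=C/c2cc(-c3cc(OC)c(OC)c(OC)c3)n[nH]2)cc1` gives 95%.

In a functional assay on HT-29 cells (Homo sapiens) for cytotoxicity, read by sulforhodamine B assay, with a stated time of 48 h, tested at 1 uM (a lower number here means a stronger effect, a higher number a weaker effect of the compound at the concentration tested), compound 2 stands lowest of the three numbers, with compound 1 nearest above it and compound 3 furthest above it, both beyond the scatter. Compound 4 `COc1cc(C(=O)/C=C/c2cc(-c3cc(OC)c(OC)c(OC)c3)n[nH]2)cc(OC)c1OC` differs from compound 2 by methoxy in place of hydrogen on an aromatic carbon. Among the measured compounds shown here, the only measured step, a number 13 percentage points higher from compound 1 to compound 3 (beyond the scatter), concerns a different replacement, so no measured step bears directly on this change. A small rise or no step beyond the scatter is expected here. The expected value for compound 4 is 75%, with a range of 60% to 90%. This estimate amounts to an expected step of a number 7 percentage points higher from compound 2 to compound 4 (within the scatter).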

Compound 4, a percentage reported as activity, at one concentration (the size of the read-out at that concentration, not a potency): 96%
Estimate against measurement, compound 4: 21 percentage points below; measured number outside the range, above it.
By their numbers in this assay, from the lowest: compound 2; then compound 1; then compounds 3 and 4 (each within the scatter of the next).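

In this assay, methoxy in place of hydrogen on this aromatic carbon, ortho to a methoxy group and meta to a large group, gives a number 28 percentage points higher from compound 2 to compound 4 (beyond the scatter), so the hydrogen-bearing position is not indifferent to this change and the added methoxy goes with a weaker effect at the concentration tested. The earlier step concerned only methoxy in place of amino, at a different place. Nothing at hand explains this rise. Going by these compounds, whether a hydroxyl, a fluorine or an amine at this carbon would also raise the number remains open.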